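Replacing the Methoxyphenyl Group: Expectation for Compound 3

The source may hold more compounds than are shown below. What is called first, only, known or untested is meant among the compounds shown, and "the series" means these compounds.

Measured so far in an assay on microsomes from liver for inhibition of 3-hydroxy-3-methylglutaryl-coenzyme A reductase (Rattus norvegicus); a higher number here means a weaker inhibitor, a lower number a stronger inhibitor:
compound 1 `Cc1cccc(-c2nc(C(F)(F)F)n(CC[C@@H](O)C[C@@H](O)CC(=O)O)c2-c2ccc(F)cc2)c1` gives 29 nM
compound 2 `COc1cccc(-c2nc(C(F)(F)F)n(CC[C@@H](O)C[C@@H](O)CC(=O)O)c2-c2ccc(F)cc2)c1` gives 20 nM

Among the measured compounds shown here, compound 2 has the lowest of the two numbers, but the only measured step, a 1.5-fold lower number from compound 1 to compound 2 (0.16 log units; within the scatter), is within the scatter, so the two compounds cannot be told apart on these data.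

Compound 3 `O=C(O)C[C@H](O)C[C@H](O)CCn1c(C(F)(F)F)nc(-c2ccc(F)cc2)c1-c1ccc(F)cc1` carries a change of a different kind: 4-fluorophenyl in place of 3-methoxyphenyl on an aromatic carbon. For the measured compounds named here, the one measured step concerned methyl against methoxy at the same position and was within the scatter; no step on record touches a 4-fluorophenyl group there, so nothing points to a shift in either direction. For this reason the number for compound 3 in this assay is expected to stay close to that of compound 2, with an estimated step of a 1.3-fold higher number from compound 2 to compound 3 (0.10 log units; within the scatter). The estimate for compound 3 is 25 nM, with a range from 8 nM to 80 nM.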

Compound 3, half-maximal inhibitory concentration: 38 nM
The estimate for compound 3 lay 1.5-fold (0.18 log units) below the measured number, within the range that was stated.
By their numbers in this assay, from the lowest: compounds 2, 1 and 3 (each within the scatter of the next).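

In this assay, 4-fluorophenyl in place of 3-methoxyphenyl gives a 1.9-fold higher number from compound 2 to compound 3 (0.28 log units; within the scatter) and 4-fluorophenyl in place of 3-methylphenyl gives a 1.3-fold higher number from compound 1 to compound 3 (0.12 log units; within the scatter) on the same aromatic carbon. This position has now carried a substituted phenyl ring with fluorine, methoxy or methyl, at either of two ring places, with no step beyond the scatter, so these three groups cannot be told apart here. No supporting data explain this similarity.

Going by these compounds, whether the same holds for a pyridyl ring, a cyclohexyl group or an amine on this carbon remains open. All three compounds also share the trifluoromethyl group, so the effect of a methyl or an ethyl group in its place is an open question too.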